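Trading one five-membered ring for another on a hydroxamate

A few compounds are considered here, and "the series" means these few. Any claim that something is new, unique, unknown or untested is made for them only; others in the source may bear on it.

Measured so far in a functional assay on PC-3 cells (Homo sapiens) for inhibition, read by MTT assay; a lower number here means a stronger inhibitor, a higher number a weaker inhibitor:
compound 1, `NC(=O)N1N=C(c2ccccc2)CC1c1ccccc1OCC(=O)NO`: 18700 nM
compound 2, `Cc1ccc(-c2nnc(NC(=O)CCCCCCC(=O)NO)s2)s1`: 880 nM
compound 3, `O=C(CCCCCCC(=O)Nc1nnc(-c2ccc(Br)o2)s1)NO`: 880 nM

Compound 3 stands level with compound 2 at the digits shown, and the two together sit lowest of the three; compound 1 lies far above them. Compound 4, `O=C(CCCCCCC(=O)Nc1nnc(-c2cccs2)s1)NO`, differs from compound 3 by thiophen-2-yl in place of 5-bromofuran-2-yl on an aromatic carbon. Among the measured compounds shown here, the one step that bears on this is no change at the digits printed from compound 2 to compound 3 (within the scatter), which also exchanged one five-membered aromatic ring for another at the same place and left the number unchanged within the scatter. A step of about that size, none beyond the scatter, is therefore expected for a 1.0-fold higher number from compound 3 to compound 4 (0.01 log units; within the scatter). Compound 4 is accordingly estimated at 900 nM, with a range from 400 nM to 2000 nM.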

Compound 4, half-maximal inhibitory concentration: 880 nM
For compound 4 the middle estimate is 1.0-fold (0.01 log units) above the measured one; the range from low to high includes it.
By their numbers in this assay, from the lowest: compounds 2, 3 and 4 (each within the scatter of the next); then compound 1.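

In this assay, the swap to thiophen-2-yl on this aromatic carbon gives no change at the digits printed from compound 3 to compound 4 (within the scatter), and hydrogen in place of methyl on the same ring gives no change at the digits printed from compound 2 to compound 4 (within the scatter). Neither the bromine of compound 3 nor the methyl of compound 2 is therefore needed to hold the number, and the furan oxygen and thiophene sulfur also exchange without a step beyond the scatter in this set. Nothing available explains this tolerance. Going by these compounds, whether a phenyl ring at this carbon would stay level remains open. So does the effect of an amine on the thiophen-2-yl ring or a longer chain leading to the hydroxamate.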